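This account rests on a few compounds, and the source may have more. Where it says the series, first, only, none or still open, it means among the compounds named here.

Three compounds share one core and differ only in the group attached to the sulfonyl sulfur. Compound 1 `CC1(C)C=C(n2ccccc2=O)c2cc(S(=O)(=O)N=[N+]=[N-])ccc2O1` carries an azido group there, and in a functional assay on the whole organism (trachea) with Rattus norvegicus as the target (on this read-out lower numbers stand for smaller maximal responses and higher numbers for larger maximal responses), compound 1 gives 77.2%. Compound 2 `CNS(=O)(=O)c1ccc2c(c1)C(n1ccccc1=O)=CC(C)(C)O2` carries a methylamino group, and in this assay compound 2 gives 83%. Compound 3 `CC1(C)C=C(n2ccccc2=O)c2cc(S(=O)(=O)Nc3ccc(C#N)cc3)ccc2O1` carries a (4-cyanophenyl)amino group, and in this assay compound 3 gives 90.8%, the highest of the three numbers, though its step to compound 2 stays within the scatter while its step to compound 1 lies beyond it.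

The measured steps are a number 5.8 percentage points higher from compound 1 to compound 2 (within the scatter), a number 13.6 percentage points higher from compound 1 to compound 3 (beyond the scatter) and a number 7.8 percentage points higher from compound 2 to compound 3 (within the scatter). Only the last one crossed the scatter, and it was modest.

Compound 4 `CC1(C)C=C(n2ccccc2=O)c2cc(S(=O)(=O)Oc3ccccc3)ccc2O1` differs from compound 3 by phenoxy in place of (4-cyanophenyl)amino on a sulfonyl sulfur. Among the measured compounds shown here, all three measured steps concern the same position, and they show that swapping one sulfonyl substituent for another has shifted the read-out by small amounts, with only the step from the azido to the (4-cyanophenyl)amino group crossing the scatter. An aromatic ring stays in place, so compound 4 is expected to remain near compound 3, with a number 5.8 percentage points lower from compound 3 to compound 4 (within the scatter) and no step beyond the scatter. The estimate for compound 4 in this assay is 85%, within 72% to 96%.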

Compound 4, largest response reached (Emax), in percent of the reference or control that the assay uses: 86.7%
Beside the measured number, compound 4's estimate is 1.7 percentage points below it; measured number inside the range.
By their numbers in this assay, from the lowest: compounds 1, 2, 4 and 3 (each within the scatter of the next, the first and the last beyond it).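

Replacing (4-cyanophenyl)amino with phenoxy on the sulfonyl sulfur removes the nitrile and the hydrogen-bond donor of the leaving group, yet in this assay this gives a number 4.1 percentage points lower from compound 3 to compound 4 (within the scatter), so a sulfonyl substituent without either feature can still give a read-out that cannot be told apart from that of compound 3. The same holds against the smaller methylamino group, with a number 3.7 percentage points higher from compound 2 to compound 4 (within the scatter), and against the azido group, with a number 9.5 percentage points higher from compound 1 to compound 4 (within the scatter), so unlike the (4-cyanophenyl)amino group, phenoxy does not separate from the azido group beyond the scatter, and compound 4 lies within the scatter of all three earlier compounds. No measurement is available that explains why these numbers lie so close together.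

The compounds shown leave open whether the nitrile, the ring or the atom linking the ring to the sulfur accounts for the one step beyond the scatter, since this change alters the nitrile and the linking atom together and a plain phenylamino group would separate them. They also leave open how far this position tolerates other kinds of group, such as a dimethylamino group, a longer chain like butylamino, or a phenoxy ring carrying a carboxylic acid.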